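Azaindazole amidine series: cytotoxicity notes and a new analogue

The source may report more compounds than this note shows. Statements on the series, on what has been measured and on what is new or still open speak of the compounds shown alone.

Measured compounds:
Compound 1 `CN1CCN(c2ccc(NC(=N)c3cc4cnn(C)c4cn3)cc2)CC1` — in a functional assay on HT-1080 cells (Homo sapiens) for cytotoxicity, read by MTT assay, with a stated time of 72 h (on this read-out lower numbers stand for stronger inhibition and higher numbers for weaker inhibition), compound 1 gives 24000 nM.
Compound 2 `COc1ccc(Cn2ncc3cc(C(=N)Nc4ccc(N5CCN(C)CC5)cc4)ncc32)cc1` — in this assay compound 2 gives 5300 nM.
Compound 3 `Cn1cc2cc(C(=N)Nc3ccccc3)ncc2n1` — in this assay the entry for compound 3 reads "not determined" (no result reported); no single number was obtained.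

Going by the values given here, the one measured pair that differs in a single place is compound 1 to compound 2. The change is 4-methoxyphenyl in place of hydrogen on a saturated chain carbon bound to an aromatic nitrogen, and on this read-out it moved the number as follows: a 4.5-fold lower number from compound 1 to compound 2 (0.66 log units; beyond the scatter). A modest but real gain, then, for adding the 4-methoxyphenyl at that saturated chain carbon bound to an aromatic nitrogen.

Compound 3 carries a different core from compound 1; the difference between the two cores is not broken down here. Compound 4 `COc1ccc(Cn2cc3cc(C(=N)Nc4ccccc4)ncc3n2)cc1` stands to compound 3 as compound 2 stands to compound 1: the change is 4-methoxyphenyl in place of hydrogen on a saturated chain carbon bound to an aromatic nitrogen, the same change at the same place.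

With no number for compound 3, the expectation for compound 4 cannot be built by adding the step to a measured parent. Among the compounds with values here, it rests instead on the measured pair alone: compound 2 sits at 5300 nM after this change, and compound 4 is expected to land in a similar region because a 4.5-fold lower number from compound 1 to compound 2 (0.66 log units; beyond the scatter) is the only guide to what the change does in this assay. Compound 4 is estimated at 10000 nM, with a wide range from 2000 nM to 50000 nM given that the two cores are not directly compared.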

Compound 4, half-maximal inhibitory concentration: 1130 nM
The estimate for compound 4 lay 8.8-fold (0.95 log units) above the measured number, and the stated range ends above it.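

No step can be read from compound 3 to compound 4: compound 3 has no single number in this assay, and compound 4 stands alone at 1130 nM. The compounds shown leave open whether 4-methoxyphenyl in place of hydrogen acts on the core of compound 3 with a size like a 4.5-fold lower number from compound 1 to compound 2 (0.66 log units; beyond the scatter). No evidence at hand bears on the result for compound 4.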